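Trading a tert-butyl for a hydroxy group

The compounds below may be only part of what the source reports. "The series", "measured", "known", "first", "only" and "open" are said of these compounds alone.

Compound 1 `CC(C)(C)c1ccc(C(=O)N/N=C/c2ccc(O)cc2)cc1` and compound 2 `CC(C)(C)c1ccc(C(=O)N/N=C/c2cc(O)cc(O)c2)cc1` share one core and differ in a single part of the structure. In a physicochemical assay, read by spectrophotometry, with a stated time of 60 min, tested at 1000 uM (a higher number here means a stronger effect of the compound at the concentration tested, a lower number a weaker effect), compound 1 gives 38.7%. In this assay compound 2 gives 31.3%. These two numbers lie within the usual scatter of each other, so compound 2 stands level with compound 1 rather than apart from it. Compound 3 `O=C(N/N=C/c1cc(O)cc(O)c1)c1ccc(O)cc1` has not yet been measured; it differs from compound 2 by hydroxy in place of tert-butyl on an aromatic carbon. Within the data shown here, no measured pair shows this change, so no step beyond the scatter is expected in either direction. Compound 3 is therefore expected to give about 32%, between 15% and 50%. For compound 3 this estimate means a step of a number 0.7 percentage points higher from compound 2 to compound 3 (within the scatter), expected to stay within the scatter.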

Compound 3, a percentage reported as inhibition, at one concentration (the size of the read-out at that concentration, not a potency): 34.2%
Beside the measured number, compound 3's estimate is 2.2 percentage points below it, and the stated range covers the measured number.
By their numbers in this assay, from the lowest: compounds 2, 3 and 1 (each within the scatter of the next).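

In this assay putting hydroxy in place of tert-butyl on an aromatic carbon gives a number 2.9 percentage points higher from compound 2 to compound 3 (within the scatter) as the step. Among these compounds, this is the first view of this position, and it shows that a large all-carbon group can give way to a single oxygen bearing a hydrogen-bond donor and acceptor with no step beyond the scatter in this read-out. Nothing available here bears on what lies behind this result.

On these data alone, whether an amine or a carboxylic acid at this position would stay within the scatter remains open. A longer chain there is equally untested by the compounds shown.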